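Replacing one substituted phenyl group with another on compound 3

A few compounds are considered here, and "the series" means these few. Any claim that something is new, unique, unknown or untested is made for them only; others in the source may bear on it.

In a functional assay on A-375 cells (Homo sapiens) for antiproliferative activity, read by MTT assay, with a stated time of 24 h (a higher number here means a weaker inhibitor, a lower number a stronger inhibitor), compound 1 `C#CCOc1ccc2c(=O)c(-c3cc(OC)c(OC)cc3OC)coc2c1` gives 3680 nM, compound 2 `COc1cc(OC)c(-c2coc3cc(OCc4ccc(F)cc4)ccc3c2=O)cc1OC` gives 1720 nM and compound 3 `COc1cc(OC)c(-c2coc3cc(OCc4ccccc4C#N)ccc3c2=O)cc1OC` gives 990 nM. Compound 3 cannot be separated from the 4-fluorophenyl compound, as the data show a 1.7-fold lower number from compound 2 to compound 3 (0.24 log units; within the scatter). It does stand apart from the ethynyl compound, with a 3.7-fold lower number from compound 1 to compound 3 (0.57 log units; beyond the scatter), and the 4-fluorophenyl compound shows a similar move, a 2.1-fold lower number from compound 1 to compound 2 (0.33 log units; beyond the scatter).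

Compound 4 `COc1cc(OC)c(-c2coc3cc(OCc4cccc(C(F)(F)F)c4)ccc3c2=O)cc1OC` keeps the shared core and changes one group: 3-(trifluoromethyl)phenyl in place of 2-cyanophenyl on a saturated chain carbon bound to an oxygen on an aromatic ring. In words, 3-(trifluoromethyl)phenyl comes in place of 2-cyanophenyl on a saturated chain carbon bound to an oxygen on an aromatic ring. Going by the values given here, the closest precedent is the exchange of one substituted phenyl for another, a 1.7-fold lower number from compound 2 to compound 3 (0.24 log units; within the scatter), which stayed within the scatter. The larger steps replaced ethynyl, which is not what happens here. Among the compounds with values here, no measured compound carries trifluoromethyl, so the expectation is loose and no shift beyond the scatter is anticipated in this assay. The expected step is a 1.4-fold higher number from compound 3 to compound 4 (0.15 log units; within the scatter). Compound 4 is estimated at 1400 nM, with an expected range of 600 nM to 3300 nM.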

Compound 4, half-maximal inhibitory concentration: 1140 nM
For compound 4 the middle estimate is 1.2-fold (0.09 log units) above the measured one; low and high end bracket the measured number.
By their numbers in this assay, from the lowest: compounds 3, 4 and 2 (each within the scatter of the next); then compound 1.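

In this assay, a third substituted phenyl group at this place, on a saturated chain carbon bound to an oxygen on an aromatic ring, gives no separable change, with a 1.2-fold higher number from compound 3 to compound 4 (0.06 log units; within the scatter) and a 1.5-fold lower number from compound 2 to compound 4 (0.18 log units; within the scatter), so the 2-cyanophenyl, 4-fluorophenyl and 3-(trifluoromethyl)phenyl compounds cannot be told apart here. Compound 4 also repeats the move away from the ethynyl compound, with a 3.2-fold lower number from compound 1 to compound 4 (0.51 log units; beyond the scatter), so all three substituted phenyl groups now stand apart from ethynyl. Nothing available explains why these numbers fall as they do.

From the compounds shown here alone, it remains open what an amine or a carboxylic acid would do at this place. Also open, going by these compounds, is whether a longer chain carrying these phenyl groups would keep the number near that of compound 3.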